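The source may hold more compounds than are shown below. What is called first, only, known or untested is meant among the compounds shown, and "the series" means these compounds.

Two compounds share one core and differ only in the group carried on an aromatic nitrogen. Compound 1 `COc1cc2c(cc1NS(=O)(=O)c1cccc(Cl)c1Cl)[nH]c(=O)n2CC(N)=O` carries a carbamoylmethyl group there, and in a functional assay on CHO cells for antagonist activity at C-C chemokine receptor type 4 (Homo sapiens), read by radioligand binding and GTPgammaS binding (on this read-out higher numbers stand for weaker inhibition and lower numbers for stronger inhibition), compound 1 gives 457 nM. Compound 2 `COc1cc2c(cc1NS(=O)(=O)c1cccc(Cl)c1Cl)[nH]c(=O)n2C(CO)CO` carries a 2-hydroxy-1-(hydroxymethyl)ethyl group instead, and in this assay compound 2 gives 1580 nM. That exchange was measured as a 3.5-fold higher number from compound 1 to compound 2 (0.54 log units; beyond the scatter). Among the compounds with values here, compound 2 thus has the higher of the two numbers, with compound 1 as its only neighbour.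

Compound 3 `COc1cc2c(cc1NS(=O)(=O)c1cccc(Cl)c1Cl)[nH]c(=O)n2C1CNC1` has not been measured. It differs from compound 2 in one place: azetidin-3-yl in place of 2-hydroxy-1-(hydroxymethyl)ethyl on an aromatic nitrogen. Within the data shown here, the only measured step that bears on this position is the one from compound 1 to compound 2, which showed a modest change when one group on that nitrogen was swapped for another. Among the measured compounds shown here, no step involving an azetidin-3-yl group exists among the measured pairs, so the expectation rests on the finding that changes at this nitrogen shifted this assay by a modest amount in either direction. Compound 3 is therefore expected to show a step of a 2.0-fold lower number from compound 2 to compound 3 (0.30 log units; within the scatter). The estimate for compound 3 in this assay is 800 nM, with a range from 250 nM to 2500 nM.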

Compound 3, half-maximal inhibitory concentration in the C-C chemokine receptor type 4 assay: 398 nM
For compound 3 the middle estimate is 2.0-fold (0.30 log units) above the measured one; the range from low to high includes it.
By their numbers in the C-C chemokine receptor type 4 assay, from the lowest: compounds 3 and 1 (each within the scatter of the next); then compound 2.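

In the C-C chemokine receptor type 4 assay, the azetidin-3-yl group gives a clear drop, a 4.0-fold lower number from compound 2 to compound 3 (0.60 log units; beyond the scatter), while its exchange for carbamoylmethyl leaves no readable difference, a 1.1-fold lower number from compound 1 to compound 3 (0.06 log units; within the scatter). This aromatic nitrogen can therefore carry a small four-membered ring with a ring nitrogen and give a number level with that of the open carbamoylmethyl chain, which leaves the 2-hydroxy-1-(hydroxymethyl)ethyl group as the one that stands apart among these three compounds. The exchange that lowers the number in the receptor assay also raises lipophilicity, so the two read-outs move together for this one pair, as shown in a physicochemical assay for lipophilicity, at pH 7.4; on this read-out lower numbers stand for lower lipophilicity and higher numbers for higher lipophilicity: the measured distribution coefficient of compound 2, 2.1, and of compound 3, 3, a number 0.90 log units higher (beyond the scatter)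
In the physicochemical assay compound 2 gives 2.1 and compound 3 gives 3 on this read-out.

A single pair cannot say whether these two shifts are linked or merely occur together. As far as these compounds go, it also stays open whether the ring nitrogen itself matters, which an oxetan-3-yl group, with oxygen in that ring place, could test, and whether a larger ring such as piperidin-4-yl or a simple open-chain aminoethyl group would give a number like that of compound 3.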